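Changing the pyrrolidine substituent of compound 2

The source may hold more compounds than are shown below. What is called first, only, known or untested is meant among the compounds shown, and "the series" means these compounds.

Among the measured compounds shown here, in a functional assay on HCC827 cells (Homo sapiens) for antiproliferative activity, read by MTT assay, with a stated time of 72 h (on this read-out higher numbers stand for weaker inhibition and lower numbers for stronger inhibition), compound 2 `CN1CCN(c2ccc(Nc3ncc4nc(Nc5ccccc5)n([C@H]5CCN(C(=O)OC(C)(C)C)C5)c4n3)cc2)CC1` gives 110 nM, the lowest of the three numbers measured so far. Compound 1 `CN1CCN(c2ccc(Nc3ncc4nc(Nc5ccc(F)cc5)n([C@@H]5CCN(C(=O)CO)C5)c4n3)cc2)CC1` gives 350 nM, and compound 3 `CN1CCN(c2ccc(Nc3ncc4nc(Nc5ccc(F)cc5)n([C@H]5CCN(C(=O)OC(C)(C)C)C5)c4n3)cc2)CC1` gives 580 nM. Compound 4 `CN1CCN(c2ccc(Nc3ncc4nc(Nc5ccccc5)n([C@@H]5CCN(S(=O)(=O)C6CC6)C5)c4n3)cc2)CC1` is still unmeasured. On an aromatic nitrogen it carries 1-(cyclopropylsulfonyl)pyrrolidin-3-yl in place of 1-(tert-butoxycarbonyl)pyrrolidin-3-yl on an aromatic nitrogen.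

For the measured compounds named here, only one measured step changes this substituent, and it shows a 1.7-fold higher number from compound 1 to compound 3 (0.22 log units; within the scatter), so exchanging the group there made no difference beyond the scatter. The other step, a 5.3-fold higher number from compound 2 to compound 3 (0.72 log units; beyond the scatter), is fluoro in place of hydrogen on an aromatic carbon, and it does not bear directly on this change. Going by the values given here, no measured compound carries a cyclopropylsulfonyl group, so the expectation stays loose. The expected change is a 1.4-fold higher number from compound 2 to compound 4 (0.13 log units; within the scatter), which would not go beyond the scatter. For compound 4 the estimated value is 150 nM, with an expected range of 50 nM to 450 nM.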

Compound 4, half-maximal inhibitory concentration: 0.88 nM
Compound 4: the middle estimate sits 170-fold (2.23 log units) above what was measured, outside the stated range (below it).
By their numbers in this assay, from the lowest: compound 4; then compound 2; then compounds 1 and 3 (each within the scatter of the next).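

In this assay, among the compounds shown here, the group carried on the pyrrolidine nitrogen proves able to move the number strongly: a 130-fold lower number from compound 2 to compound 4 (2.10 log units; beyond the scatter), whereas the only earlier exchange of this substituent stayed within the scatter. The position on the aromatic nitrogen is therefore not indifferent to what it carries, and the earlier step between two carbonyl-linked groups gave no sign of this. Nothing available here accounts for the size of this step.

The two structures are also drawn with opposite configurations at the pyrrolidin-3-yl stereocentre, so the compounds shown do not separate the effect of the cyclopropylsulfonyl group from that of the configuration. They also leave open whether a methylsulfonyl group or the free pyrrolidine amine would give a similar number, and whether fluoro on the anilino group would raise the number alongside cyclopropylsulfonyl.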